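Adding a methoxy to the phenyl of a sigma-1 ligand

This account rests on a few compounds, and the source may have more. Where it says the series, first, only, none or still open, it means among the compounds named here.

Of the compounds shown here, three sharing one core have been measured in an assay on membranes from brain for displacement of a labelled ligand from Sigma non-opioid intracellular receptor 1 (Cavia porcellus), read by scintillation counting, with a stated time of 120 min; on this read-out higher numbers stand for weaker inhibition and lower numbers for stronger inhibition. Compound 1 `COC1Cc2c(csc2-c2ccc(C(C)=O)cc2)C2(CCN(Cc3ccccc3)CC2)O1` gives 1.6 nM, compound 2 `c1ccc(CN2CCC3(CC2)OCCc2cc(-c4ccccc4)sc23)cc1` gives 2.4 nM, and compound 3 `COC1Cc2cc(-c3ccccc3)sc2C2(CCN(Cc3ccccc3)CC2)O1` gives 16 nM, the highest of the three. Within the data shown here, the only single-place step measured, a 6.7-fold higher number from compound 2 to compound 3 (0.82 log units; beyond the scatter), concerns a saturated ring carbon. Compound 4 `COc1ccc(-c2cc3c(s2)C2(CCN(Cc4ccccc4)CC2)OC(OC)C3)cc1` differs from compound 3 by methoxy in place of hydrogen on an aromatic carbon. No measured step touches this aromatic ring, so nothing shown points in either direction. The expected change from compound 3 to compound 4 in this assay is a 1.1-fold lower number from compound 3 to compound 4 (0.06 log units; within the scatter), no more than the scatter. Compound 4 is therefore expected to give about 14 nM, within a range from 5 nM to 40 nM.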

Compound 4, inhibition constant: 56 nM
Compound 4: the middle estimate sits 4.0-fold (0.60 log units) below what was measured; measured number above the stated range.
By their numbers in this assay, from the lowest: compounds 1 and 2 (each within the scatter of the next); then compound 3; then compound 4.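

On the phenyl ring, the change from phenyl to 4-methoxyphenyl gives a 3.5-fold higher number from compound 3 to compound 4 (0.54 log units; beyond the scatter) in this assay and so weakens inhibition. Among these compounds, this is the first measured step on this ring, and it shows that a methoxy placed para to a large group is not a silent change here. Together with the earlier step on the saturated ring carbon, it shows that a methoxy at either of these two places goes with a higher number.

Going by these compounds, whether a hydroxyl, a fluorine or an amine at this same place would also raise the number remains open. Nothing given here explains this rise.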